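Swapping a methoxy for a pyrrolidine amide

The source may hold more compounds than are shown below. What is called first, only, known or untested is meant among the compounds shown, and "the series" means these compounds.

Compound 1 `COc1ccc(N2C(=O)N/C(=C\c3ccc(O)cc3)C2=O)cc1` is tested in a functional assay on NCI-H292 cells (Homo sapiens) for antiproliferative activity (a higher number here means a weaker inhibitor, a lower number a stronger inhibitor), where compound 1 gives > 200000 nM, which is only a limit of the assay and not a measured number (the limit of > 200000 nM in this assay, at which 1 of the 2 values shown sits). Compound 2 `O=C(NCC1CCCCC1)c1cccc(N2C(=O)N/C(=C\c3ccc(O)cc3)C2=O)c1` carries a different amide, and in this assay compound 2 gives 17900 nM. Compound 3 `O=C(c1ccc(N2C(=O)N/C(=C\c3ccc(O)cc3)C2=O)cc1)N1CCCC1` differs from compound 1 by (pyrrolidin-1-yl)carbonyl in place of methoxy on an aromatic carbon, para to a large group. A step toward stronger inhibition, beyond the usual scatter, is expected. For compound 3 the estimated value is 40000 nM (range 10000 nM to 200000 nM), meaning an expected step of an at least 5.0-fold lower number from compound 1 to compound 3 (0.69 log units; beyond the scatter).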

Compound 3, half-maximal inhibitory concentration: > 200000 nM
Compound 3: only a limit was reported (the forecaster's own chance of this, stated with the estimate: 25%); middle value at least 5.0-fold (0.69 log units) away from the limit.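

Compound 1 and compound 3 both stop at a limit of the assay, so no step between them can be read: the limit of > 200000 nM in this assay, at which 2 of the 3 values shown sit.

Still open, going by these compounds, is how far (pyrrolidin-1-yl)carbonyl in place of methoxy really shifts the result in this assay.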